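A few compounds are considered here, and "the series" means these few. Any claim that something is new, unique, unknown or untested is made for them only; others in the source may bear on it.

Compound 1 `Cn1cnc(-c2nc(N)c3cc(Cc4ccccc4)sc3n2)c1` carries a 1-methyl-1H-imidazol-4-yl group on the shared core, and in a functional assay on CHO-K1 cells for antagonist activity at adenosine receptor A1 (Homo sapiens), read by a beta-galactosidase reporter and cAMP accumulation, with stated times of 15 min and 6 h (a lower number here means a stronger inhibitor, a higher number a weaker inhibitor), compound 1 gives 2330 nM, the highest number of the two measured here. Compound 2 `N#Cc1cccc(-c2nc(N)c3cc(Cc4ccccc4Cl)sc3n2)c1` gives 24.8 nM in this assay, a much lower number than that of compound 1, well beyond the scatter; compound 2 differs from compound 1 in more than one place, so no single-change step can be read from that pair. Compound 3 `N#Cc1cncc(-c2nc(N)c3cc(Cc4ccccc4)sc3n2)c1` keeps the unsubstituted benzyl of compound 1 and differs from it only by the change (5-cyanopyridin-3-yl in place of 1-methyl-1H-imidazol-4-yl on an aromatic carbon). Among the measured compounds shown here, no measured pair isolates this change, yet the nitrile-bearing ring of compound 2 is the closer relative. The step from compound 1 to compound 3 is expected to be a large fall in the number, a 19-fold lower number from compound 1 to compound 3 (1.29 log units; beyond the scatter). Compound 3 is therefore estimated at 120 nM in this assay, within 30 nM to 500 nM.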

Compound 3, inhibition constant: 1160 nM
Estimate against measurement, compound 3: 9.7-fold (0.99 log units) below, and the stated range ends below it.
By their numbers in this assay, from the lowest: compound 2; then compounds 3 and 1 (each within the scatter of the next).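

In this assay, 5-cyanopyridin-3-yl can take the place of 1-methyl-1H-imidazol-4-yl on the aromatic carbon between two ring nitrogen atoms with only a 2.0-fold lower number from compound 1 to compound 3 (0.30 log units; within the scatter), so with the unsubstituted benzyl kept, these two rings cannot be told apart. The 5-cyanopyridin-3-yl group alone therefore does not bring the number down to that of compound 2, which differs from both other compounds in more than one place, so its value cannot be traced to any single change. Nothing available explains why this exchange leaves the number so little moved.

Among the compounds shown here, no pair here isolates the chlorine on the benzyl ring of compound 2, so its share in that low number remains open. Also open, on these data alone, is how this position would respond to a plain phenyl ring, a morpholine or a carboxylic acid.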